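The source may report more compounds than this note shows. Statements on the series, on what has been measured and on what is new or still open speak of the compounds shown alone.

Compound 1, `Cn1nnnc1SCC(=O)N/N=C/c1ccccc1`, gives 3160000 nM in a functional assay on A549 cells (Homo sapiens) for cytotoxicity, read by XTT assay, with a stated time of 24 h; on this read-out lower numbers stand for stronger inhibition and higher numbers for weaker inhibition. Compound 2, `Cn1nnnc1SCC(=O)N/N=C/c1cccc(Cl)c1`, gives 7500000 nM in this assay; the change chloro in place of hydrogen on an aromatic carbon made a step of a 2.4-fold higher number from compound 1 to compound 2 (0.38 log units; beyond the scatter). Compound 3, `C/C(=N\NC(=O)CSc1nnnn1C)c1cccc(Cl)c1`, has a different core, and the difference between the two cores is not broken down here. Compound 3 reaches only a limit in this assay, > 10000000 nM; this is the limit of > 10000000 nM in this assay, at which 1 of the 3 values shown sits. Compound 4, `C/C(=N\NC(=O)CSc1nnnn1C)c1cc(Cl)ccc1Cl`, is not yet measured and differs from compound 3 by chloro in place of hydrogen on an aromatic carbon, the same kind of change as between compound 1 and compound 2, though here the place is ortho to a large group and para to a chloro group rather than meta to a large group. Since compound 3 already sits at the limit and the earlier step of a 2.4-fold higher number from compound 1 to compound 2 (0.38 log units; beyond the scatter) raised the number, a step that the limit leaves unreadable from compound 3 to compound 4 is expected, most likely again as a limit. Compound 4 is estimated at 15000000 nM, between 5000000 nM and 50000000 nM.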

Compound 4, half-maximal inhibitory concentration: 1500000 nM
Compound 4: the middle estimate sits 10-fold (1.00 log units) above what was measured; the measured number lies below the stated range.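

Chloro in place of hydrogen on an aromatic carbon did not carry from one core to the other in this assay as a fixed step; on the second core the step was an at least 6.6-fold lower number from compound 3 to compound 4 (0.82 log units; beyond the scatter), opposite in direction to the earlier one: the same change on two cores in this assay, a 2.4-fold higher number (0.38 log units; beyond the scatter) from compound 1 to compound 2 and an at least 6.6-fold lower number (0.82 log units; beyond the scatter) from compound 3 to compound 4, at least 15-fold (1.19 log units) apart, beyond the scatter of two such steps

The value of compound 3 is a limit, so this step gives only a bound on the change: the limit of > 10000000 nM in this assay, at which 1 of the 4 values shown sits.

With one pair on each core, and the new chloro ortho to a large group and para to a chloro group, the data do not show whether the reversal follows the core or the place of the chloro. On these data alone, how a bromo or a methoxy group on that same aromatic carbon would behave on either core remains open.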